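This account rests on a few compounds, and the source may have more. Where it says the series, first, only, none or still open, it means among the compounds named here.

Working notes on the series. In a functional assay on HL-60 cells (Homo sapiens) for cytotoxicity, read by MTT assay, with a stated time of 48 h (on this read-out lower numbers stand for stronger inhibition and higher numbers for weaker inhibition), compound 1 `Cc1ccc(Cn2c(/C=C3\SC(=S)N(CC(=O)O)C3=O)nc3cc(Cl)ccc32)cc1` gives 2720 nM, and compound 2 `Cc1ccc(Cn2c(/C=C3\SC(=S)N(CC(=O)O)C3=O)nc3ccc(Cl)cc32)cc1` gives 2840 nM; the two numbers lie within the usual scatter of each other. How the two cores differ is not broken down here. Compound 3 `Cc1ccc(Cn2c(/C=C3\SC(=S)N(CC(=O)O)C3=O)nc3cc(F)ccc32)cc1` gives 1170 nM in this assay; its change from compound 1, (fluoro in place of chloro on an aromatic carbon), made the step of a 2.3-fold lower number from compound 1 to compound 3 (0.37 log units; beyond the scatter). Compound 4 `Cc1ccc(Cn2c(/C=C3\SC(=S)N(CC(=O)O)C3=O)nc3ccc(F)cc32)cc1` is not yet measured; it differs from compound 2 by fluoro in place of chloro on an aromatic carbon, the same change at a place described in the same words. In this assay, for the measured compounds named here, the expected step is a 2.3-fold lower number from compound 2 to compound 4 (0.36 log units; beyond the scatter), resting on the single measured pair a 2.3-fold lower number from compound 1 to compound 3 (0.37 log units; beyond the scatter), which is a change of the same kind. Compound 4 is therefore estimated at 1250 nM, with 600 nM to 2600 nM as the expected range in this assay.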

Compound 4, half-maximal inhibitory concentration: 1690 nM
The estimate for compound 4 lay 1.4-fold (0.13 log units) below the measured number; the range from low to high includes it.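

In this assay, fluoro in place of chloro on the core of compound 2 gives a 1.7-fold lower number from compound 2 to compound 4 (0.23 log units; within the scatter). Set beside the earlier step, the change carries from one core to the other with no difference that can be told apart: the same change on two cores in this assay, a 2.3-fold lower number (0.37 log units; beyond the scatter) from compound 1 to compound 3 and a 1.7-fold lower number (0.23 log units; within the scatter) from compound 2 to compound 4, 1.4-fold (0.14 log units) apart, within the scatter of two such steps. For the compounds shown here, this rests on only two pairs and does not show that the step would hold on other cores, nor, with the new step inside the scatter, that the change has a real effect on the core of compound 2.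

The compounds shown leave open how a methoxy group, a nitrile or an amine would read on this aromatic carbon. Also open, as far as these compounds go, is whether the step would persist with an amide in place of the carboxylic acid.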